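A few compounds are considered here, and "the series" means these few. Any claim that something is new, unique, unknown or untested is made for them only; others in the source may bear on it.

The series shares one core, varied at the amide substituent. Compound 1 `CC(C(=O)NCc1ccc(Br)cc1)c1ccc(NS(C)(=O)=O)c(F)c1` gives 412 nM in an assay on CHO cells for displacement of a labelled ligand from transient receptor potential cation channel subfamily V member 1 (Rattus norvegicus); a higher number here means a weaker inhibitor, a lower number a stronger inhibitor. Compound 2 `Cc1ccc(CNC(=O)C(C)c2ccc(NS(C)(=O)=O)c(F)c2)cc1` gives 3100 nM. Compound 3 `CC(C)c1ccc(CNC(=O)C(C)c2ccc(NS(C)(=O)=O)c(F)c2)cc1` gives 127 nM, the lowest of the three numbers; its nearest neighbour is compound 1, with a 3.2-fold lower number from compound 1 to compound 3 (0.51 log units; beyond the scatter) separating them, and its furthest is compound 2, with a 24-fold lower number from compound 2 to compound 3 (1.39 log units; beyond the scatter).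

Compound 4 `CC(C(=O)NCCCc1ccc(Cl)cc1)c1ccc(NS(C)(=O)=O)c(F)c1` is not yet measured. The change from compound 3 is 2-(4-chlorophenyl)ethyl in place of 4-isopropylphenyl on a saturated chain carbon bound to an amide-type nitrogen. This alters two things at once: the group on the aromatic ring, where chloro takes the place of isopropyl, and the length of the saturated chain between the amide nitrogen and the ring. The measured steps speak only to the first: a 7.5-fold higher number from compound 1 to compound 2 (0.88 log units; beyond the scatter), a 3.2-fold lower number from compound 1 to compound 3 (0.51 log units; beyond the scatter) and a 24-fold lower number from compound 2 to compound 3 (1.39 log units; beyond the scatter) all exchange the ring substituent with the chain held constant, and the halogen of compound 1 sits between the methyl of compound 2 and the isopropyl of compound 3. Nothing measured tests a longer chain. A moderate rise from compound 3 is therefore expected, with wide uncertainty, roughly a 4.7-fold higher number from compound 3 to compound 4 (0.67 log units; beyond the scatter). Compound 4 is estimated at 600 nM, within a range of 150 nM to 3000 nM.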

Compound 4, inhibition constant: 470 nM
The estimate for compound 4 lay 1.3-fold (0.11 log units) above the measured number; the range from low to high includes it.
By their numbers in this assay, from the lowest: compound 3; then compounds 1 and 4 (each within the scatter of the next); then compound 2.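

Read in this assay, the step of a 1.1-fold higher number from compound 1 to compound 4 (0.06 log units; within the scatter) leaves 2-(4-chlorophenyl)ethyl level with 4-bromophenyl on the saturated chain carbon bound to an amide-type nitrogen, so this position accepts a group of this kind with no measurable change from compound 1. The group still stands short of 4-isopropylphenyl, with a 3.7-fold higher number from compound 3 to compound 4 (0.57 log units; beyond the scatter) as the cost, yet it clearly improves on 4-methylphenyl, with a 6.6-fold lower number from compound 2 to compound 4 (0.82 log units; beyond the scatter) as the gain, so the earlier spread among ring substituents now also holds a compound in which the chain differs. Since the chain and the ring substituent change together in compound 4, these steps do not apportion the effect to either, and no supporting data explain any of them.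

The compounds shown leave open what 4-chlorophenyl gives on the chain of compound 1, and what 4-isopropyl gives on the chain of compound 4, either of which would separate the two changes. Also open, going by these compounds, are a still longer chain and other ring substituents, such as tert-butyl, trifluoromethyl or an amine, at this position.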